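Dropping a Fluoro Group: What to Expect for Compound 4

The source may report more compounds than this note shows. Statements on the series, on what has been measured and on what is new or still open speak of the compounds shown alone.

Measured so far:
compound 1, `N/C(=N\NC(=S)N1CCSCC1)c1ccccn1`: 81.3%
compound 2, `Cc1cccc(/C(N)=N/NC(=S)N2CCCCC2)n1`: 65.2%
compound 3, `N/C(=N\NC(=S)N1CCOCC1)c1ccc(F)cn1`: 82.3%

In a functional assay on A-431 cells (Homo sapiens) for cytotoxicity, read by MTT assay, with a stated time of 72 h, tested at 30 uM (a lower number here means less inhibition of growth, a higher number more inhibition of growth at the concentration tested), compound 3 gives 82.3%, the largest of the three numbers. Compound 1, with 81.3%, lies within the usual scatter of compound 3, so the two cannot be told apart. Compound 2, with 65.2%, sits beyond the scatter, clearly lower than compound 3.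

Compound 4, `N/C(=N\NC(=S)N1CCOCC1)c1ccccn1`, has not been measured. It differs from compound 3 in one place: hydrogen in place of fluoro on an aromatic carbon. Among the measured compounds shown here, no measured pair shows this exact change on its own. Still, the same unsubstituted ring as in compound 4 is carried by compound 1, which gives 81.3%, close to compound 3. For that reason the step from compound 3 to compound 4 in this assay is expected to be small, most likely none beyond the scatter, perhaps a slight drop, which is what a number 3.3 percentage points lower from compound 3 to compound 4 (within the scatter) means. Compound 4 is therefore estimated at 79%, in a range from 66% to 88%.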

Compound 4, percent growth inhibition at one concentration: 78.8%
Compound 4: middle estimate off by 0.2 percentage points, on the high side; the measured number falls inside the stated range.
By their numbers in this assay, from the lowest: compound 2; then compounds 4, 1 and 3 (each within the scatter of the next).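

In this assay, among the compounds shown here, hydrogen in place of fluoro on this aromatic carbon, two atoms from the ring nitrogen and para to a large group, gives a number 3.5 percentage points lower from compound 3 to compound 4 (within the scatter) and provides the first direct pair for this change: with the rest of the structure held constant, fluoro and hydrogen cannot be told apart here. Morpholin-4-yl in place of thiomorpholin-4-yl on the thiocarbonyl carbon gives a number 2.5 percentage points lower from compound 1 to compound 4 (within the scatter) and adds a second direct pair in which the two compounds cannot be told apart. Nothing available explains either result.

These two pairs do not show whether a chloro, methoxy or amino group at this same ring position would also stay within the scatter. A larger group such as phenyl at this position also remains an open case.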